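The source may hold more compounds than are shown below. What is called first, only, known or untested is meant among the compounds shown, and "the series" means these compounds.

Compound 1, `CCOc1ccccc1C[C@H]1COC(=O)[C@@H]1Cc1ccc(Cl)c(Cl)c1`, carries an ethoxy group on one of its two aromatic rings, and in a functional assay on HeLa cells (Homo sapiens) for cytotoxicity, read by WST assay, with a stated time of 48 h (on this read-out higher numbers stand for an effect only at larger amounts of compound and lower numbers for an effect already at smaller amounts), compound 1 gives 31000 nM. Compound 2, `CCCCOc1ccccc1C[C@H]1COC(=O)[C@@H]1Cc1ccc(Cl)c(Cl)c1`, differs from it by ethyl in place of hydrogen on a saturated chain carbon, two bonds along the chain from an oxygen on an aromatic ring. For compound 2 the read-out in this assay is a limit of the assay, > 100000 nM, not a number. The step of an at least 3.2-fold higher number from compound 1 to compound 2 (0.50 log units; beyond the scatter) therefore rests on (the limit of > 100000 nM in this assay, at which 1 of the 3 values shown sits), and its size can only be given as a lower bound.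

Compound 3, `CCc1ccc(C[C@H]2COC(=O)[C@@H]2Cc2ccc(Cl)c(Cl)c2)cc1`, belongs to a second core; the difference between the two cores is not broken down here. In this assay compound 3 has the entry "not determined" (no result reported), so no number stands for it. Compound 4, `CCCCc1ccc(C[C@H]2COC(=O)[C@@H]2Cc2ccc(Cl)c(Cl)c2)cc1`, differs from compound 3 by ethyl in place of hydrogen on a saturated chain carbon, two bonds along the chain from an aromatic carbon. Going by the values given here, this is the same kind of change as the one from compound 1 to compound 2, though not the same: there the ethyl enters two bonds along the chain from an oxygen on an aromatic ring, here two bonds along the chain from an aromatic carbon.

With no value for compound 3, the expectation for compound 4 cannot be built as a step from it. Judged beside the step from compound 1 to compound 2 in this assay, which ended at the limit (the limit of > 100000 nM in this assay, at which 1 of the 3 values shown sits), compound 4 is expected to show an effect only at large amounts, and its estimated value in this assay is 70000 nM, with a range from 20000 nM to 150000 nM.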

Compound 4, half-maximal effective concentration: 27000 nM
For compound 4 the middle estimate is 2.6-fold (0.41 log units) above the measured one; low and high end bracket the measured number.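

Compound 3 has no number shown in this assay, and no step from it to compound 4 can be read from the new result. The compounds shown leave open what ethyl in place of hydrogen does on the core of compound 3, and whether that matches the same kind of change from compound 1 to compound 2, whose size rests on a limit: the limit of > 100000 nM in this assay, at which 1 of the 4 values shown sits.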